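The compounds below may be only part of what the source reports. "The series", "measured", "known", "first", "only" and "open" are said of these compounds alone.

Of the compounds shown here, three have so far been measured in a functional assay on HT-1080 cells (Homo sapiens), read by transwell migration, with a stated time of 24 h, tested at 1 uM; on this read-out higher numbers stand for a weaker effect at the one concentration tested and lower numbers for a stronger effect. Compound 1 `CC(=O)OCc1ccc2oc(=O)c(C(=O)Oc3cccc(Br)c3)cc2c1` gives 21.8%. Compound 2 `CC(=O)OCc1ccc2oc(=O)c(C(=O)Nc3cccc(Cl)c3)cc2c1` gives 66.9%, and compound 3 `CC(C)C(=O)OCc1ccc2oc(=O)c(C(=O)Oc3cccc(Br)c3)cc2c1` gives 37.8%. Among these three numbers compound 3 stands second highest: its nearest neighbour is compound 1, with a number 16 percentage points higher from compound 1 to compound 3 (beyond the scatter), and its furthest is compound 2. The large step of a number 45.1 percentage points higher from compound 1 to compound 2 (beyond the scatter) concerns the other end of the shared core and does not touch the chain changed below.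

Compound 4 `O=C(Oc1cccc(Br)c1)c1cc2cc([N+](=O)[O-])ccc2oc1=O` differs from compound 3 in one place: nitro in place of ((isopropylcarbonyl)oxy)methyl on an aromatic carbon. Among the measured compounds shown here, no measured pair replaces this chain with a nitro group, so the only step that bears on the change is the modest one from compound 1 to compound 3, which shows that altering this chain shifts this assay by a modest amount. A step of similar size is therefore expected, in an uncertain direction, and the estimated step of a number 7.8 percentage points lower from compound 3 to compound 4 (within the scatter) is taken as a modest decrease. Compound 4 is expected to give 30%, within the range 10% to 60%.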

Compound 4, a percentage reported as activity, at one concentration (the size of the read-out at that concentration, not a potency): 35.2%
The estimate for compound 4 lay 5.2 percentage points below the measured number; low and high end bracket the measured number.
By their numbers in this assay, from the lowest: compound 1; then compounds 4 and 3 (each within the scatter of the next); then compound 2.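

In this assay the step of a number 2.6 percentage points lower from compound 3 to compound 4 (within the scatter) shows that nitro, with 3 heavy atoms, can stand on this aromatic carbon in place of ((isopropylcarbonyl)oxy)methyl, with 7 heavy atoms, and leave the read-out within the scatter. The step of a number 13.4 percentage points higher from compound 1 to compound 4 (beyond the scatter) shows that the same nitro group does not match acetoxymethyl, so the two chains at this position cannot be treated as interchangeable with nitro. No measurement at hand explains why nitro matches one chain and not the other.

Still open, from the compounds shown here alone, is how an amine or a carboxylic acid on this aromatic carbon would read, and whether a longer ester chain would move the number further from that of compound 1. Also open, going by these compounds, is whether nitro would behave the same way on the amide of compound 2.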